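Nitro in Place of Chloro: an Expected Value for Compound 4

The source may hold more compounds than are shown below. What is called first, only, known or untested is meant among the compounds shown, and "the series" means these compounds.

Compound 1 `CC1=CC[C@H](C(C)(C)NC(=S)N/N=C/c2ccccc2Cl)CC1` gives 11000 nM.
Compound 2 `CC1=CC[C@H](C(C)(C)NC(=S)N/N=C/c2cccc(Cl)c2)CC1` gives 8000 nM.
Compound 3 `CC1=CC[C@H](C(C)(C)NC(=S)N/N=C/c2ccccc2[N+](=O)[O-])CC1` gives 1200 nM.

All three values come from a functional assay on MCF7 cells (Homo sapiens) for inhibition, read by sulforhodamine B assay, with a stated time of 48 h; a higher number here means a weaker inhibitor of growth, a lower number a stronger inhibitor of growth. Compound 1 and compound 2 have the same atoms joined differently; their cores differ by 3-chlorophenyl in place of 2-chlorophenyl on a carbon with a double bond to nitrogen, and the step of a 1.4-fold lower number from compound 1 to compound 2 (0.14 log units; within the scatter) lies within the scatter. Compound 3 differs from compound 1 by nitro in place of chloro on an aromatic carbon, and that change gave a 9.2-fold lower number from compound 1 to compound 3 (0.96 log units; beyond the scatter). Compound 4 `CC1=CC[C@H](C(C)(C)NC(=S)N/N=C/c2cccc([N+](=O)[O-])c2)CC1` has not yet been measured. For the measured compounds named here, it differs from compound 2 by nitro in place of chloro on an aromatic carbon, the same kind of change as the one between compound 1 and compound 3, though the place is not identical: in compound 3 the entering group sits ortho to a large group, in compound 4 it sits meta to a large group. For compound 4 the step expected is a 5.3-fold lower number from compound 2 to compound 4 (0.73 log units; beyond the scatter). Going by the values given here, this expectation rests on a 9.2-fold lower number from compound 1 to compound 3 (0.96 log units; beyond the scatter) and on the value of compound 2, 8000 nM, with a wider range because the place on the ring differs and only one example of the change has been measured. Compound 4 is therefore expected to give about 1500 nM in this assay, most likely between 500 nM and 5000 nM.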

Compound 4, concentration for 50% growth inhibition: > 100000 nM
Compound 4: a limit, no number; the forecaster's own chance of this, stated with the estimate: 3%; middle value at least 66-fold (1.82 log units) from the limit.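

In this assay compound 4 gives > 100000 nM, which is a limit of the assay and not a number. Nitro in place of chloro therefore did not carry over from one core to the other, for the change gave an at least 12-fold higher number from compound 2 to compound 4 (1.09 log units; beyond the scatter), against the earlier step in the opposite direction: the same change on two cores in this assay, a 9.2-fold lower number (0.96 log units; beyond the scatter) from compound 1 to compound 3 and an at least 12-fold higher number (1.09 log units; beyond the scatter) from compound 2 to compound 4, at least 110-fold (2.05 log units) apart, beyond the scatter of two such steps. This shows that, in this series, the effect of the change on one core cannot be transferred to the other, but it rests on a single pair for each core, the true size of the new step remains unknown, and the data do not show why the two steps part.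

The compounds shown leave open whether the split follows the place on the ring in general or belongs to nitro alone. They also leave open how another group in these places, such as an amine, a nitrile or a carboxylic acid, would behave on either core.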